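Phenyl for Methyl at an Aromatic Carbon

The compounds below may be only part of what the source reports. "The series", "measured", "known", "first", "only" and "open" are said of these compounds alone.

Compound 1 `CC(C)(C)NCC(O)COc1ncns1` and compound 2 `Cc1nsc(OCC(O)CNC(C)(C)C)n1` share one core and differ in a single place. In a functional assay on the whole organism (artery, strain mongrel) for inhibition, with Canis familiaris (Canis lupus familiaris) as the target, with a stated time of 20 min, at a dose of 0.1 mg/kg by the intravenous route (on this read-out lower numbers stand for a weaker effect and higher numbers for a stronger effect at the one dose given), compound 1 gives 3%, and compound 2 gives 7.7%; the two values lie within the usual scatter of each other, so compound 2 stands together with compound 1 at a small response rather than apart from it.

Compound 3 `CC(C)(C)NCC(O)COc1nc(-c2ccccc2)ns1` has not been measured. It differs from compound 2 by phenyl in place of methyl on an aromatic carbon: a phenyl, one six-membered aromatic ring of carbon only, enters where the methyl leaves, on an aromatic carbon of the five-membered aromatic ring between two ring nitrogen atoms. Among the compounds with values here, the only measured step that bears on this change is a number 4.7 percentage points higher from compound 1 to compound 2 (within the scatter), which altered the same aromatic carbon and stayed within the scatter. With nothing else to go on, no step beyond the scatter is expected here. In this assay compound 3 is therefore estimated at 9%, with a range from 0% to 30%. The implied step a number 1.3 percentage points higher from compound 2 to compound 3 (within the scatter) is expected to remain small, because a number 4.7 percentage points higher from compound 1 to compound 2 (within the scatter) was small.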

Compound 3, a percentage reported as inhibition, in the whole organism at one dose (the size of the read-out at that dose, not a potency): 3.7%
Estimate against measurement, compound 3: 5.3 percentage points above, within the range that was stated.
By their numbers in this assay, from the lowest: compounds 1, 3 and 2 (each within the scatter of the next).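

At this aromatic carbon, in this assay, the change from methyl to phenyl gives a number 4 percentage points lower from compound 2 to compound 3 (within the scatter) and the change from hydrogen to phenyl gives a number 0.7 percentage points higher from compound 1 to compound 3 (within the scatter) in the same read-out. The position has now carried hydrogen, methyl and phenyl, and the three compounds stand together at a small response; the earlier pair showed this only for a single carbon, whereas phenyl brings 6 heavy atoms and one six-membered aromatic ring of carbon only without a step beyond the scatter. Nothing available explains why the response stays together across these three groups at this position.

What the three compounds leave open is whether any other group on this aromatic carbon can give a step beyond the scatter, and an amine, a carboxylic acid or a longer chain such as butyl would each be a different kind of test from the hydrogen, methyl and phenyl shown. They also leave open whether the shared core gives a larger response at any dose other than the single one reported here.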